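This account rests on a few compounds, and the source may have more. Where it says the series, first, only, none or still open, it means among the compounds named here.

Measured so far:
Compound 1, `O=C(Nc1cccc(Cl)c1)C(Cl)Cl`, gives 44500 nM in a functional assay on Bel-7402 cells (Homo sapiens) for antiproliferative activity, read by MTT assay, with a stated time of 72 h; a higher number here means a weaker inhibitor, a lower number a stronger inhibitor.
Compound 2, `O=C(Nc1ccc(Cl)cc1)C(Cl)Cl`, gives 49600 nM in this assay.

Both compounds are weak inhibitors, and the two numbers lie within the usual scatter of repeated measurements of each other, so compound 2 cannot be set apart from compound 1 on these results. Compound 3, `O=C(Nc1ccc(Cl)c(Cl)c1)C(Cl)Cl`, is the next compound to be measured in this assay. It differs from compound 2 in one place: chloro in place of hydrogen on an aromatic carbon. Among the measured compounds shown here, no pair of measured compounds shows the effect of such a change, so the size of the step can only be guessed. A second chloro group on the ring of compound 2 is expected to change the number only modestly, likely toward a somewhat lower value, close to the edge of the scatter. Compound 3 is therefore estimated at 30000 nM, with a range from 12000 nM to 70000 nM, which corresponds to an expected step of a 1.7-fold lower number from compound 2 to compound 3 (0.22 log units; within the scatter).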

Compound 3, half-maximal inhibitory concentration: 7370 nM
For compound 3 the middle estimate is 4.1-fold (0.61 log units) above the measured one; measured number outside the range, below it.
By their numbers in this assay, from the lowest: compound 3; then compounds 1 and 2 (each within the scatter of the next).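

In this assay, a second chloro group on the aromatic ring brings a clear drop in the number (a 6.7-fold lower number from compound 2 to compound 3 (0.83 log units; beyond the scatter)), with the new chloro group ortho to the existing chloro group and meta to a group of 6 heavy atoms. Compound 3 also stands apart from the other single-chloro compound (a 6.0-fold lower number from compound 1 to compound 3 (0.78 log units; beyond the scatter)), although compound 1 and compound 2 could not be told apart from each other. Among these three compounds, then, the stronger inhibition goes with carrying both chloro groups rather than either one alone, and no measurement here explains this result.

From the compounds shown here alone, it remains open whether this gain needs chloro itself, or whether a methyl, a methoxy or an amine at the same ring position would give a similar step. The effect of a third chloro group on the ring is also unknown.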